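Three Measured Sulfones and a Dichlorophenyl Analogue

The source may report more compounds than this note shows. Statements on the series, on what has been measured and on what is new or still open speak of the compounds shown alone.

Measured compounds:
compound 1, `COc1ccc(-c2c(S(=O)(=O)c3cccc(C#N)c3)cnc3cc(F)ccc23)cc1`, 0.92 mL/min
compound 2, `N#Cc1cccc(S(=O)(=O)c2cnc3cc(F)ccc3c2-c2cccc(Cl)c2)c1`, 0.99 mL/min
compound 3, `COc1cccc(-c2c(S(=O)(=O)c3cccc(C#N)c3)cnc3cc(F)ccc23)c1`, 1.83 mL/min

Three compounds sharing one core were measured in an ADME assay on microsomes from liver (Homo sapiens) for metabolic stability, tested at 2.5 uM; on this read-out lower numbers stand for slow clearance and higher numbers for fast clearance. Compound 2 gives 0.99 mL/min, which places it second highest of the three numbers; its nearest neighbour is compound 1 with 0.92 mL/min, a gap recorded as a 1.1-fold higher number from compound 1 to compound 2 (0.03 log units; within the scatter), and its furthest is compound 3 with 1.83 mL/min, a gap recorded as a 1.8-fold higher number from compound 2 to compound 3 (0.27 log units; within the scatter). The third pair, compound 1 to compound 3, gives a 2.0-fold higher number from compound 1 to compound 3 (0.30 log units; within the scatter). All three steps concern the aryl group on the aromatic carbon of the core, and all stay within the scatter.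

Compound 4, `O=S(=O)(c1cc(Cl)cc(Cl)c1)c1cnc2cc(F)ccc2c1-c1cccc(Cl)c1`, has not yet been measured. It differs from compound 2 at a different place: 3,5-dichlorophenyl in place of 3-cyanophenyl on a sulfonyl sulfur. For the measured compounds named here, none of the measured steps touches the group on the sulfonyl sulfur, so no measured step bears directly on this change, and the three steps that are known were all small. On that basis, in this assay the step from compound 2 to compound 4 is expected to be a 1.3-fold higher number from compound 2 to compound 4 (0.12 log units; within the scatter), with no clear direction beyond the scatter. Compound 4 is therefore estimated at 1.3 mL/min, within a range from 0.6 mL/min to 2.8 mL/min.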

Compound 4, intrinsic clearance in a liver preparation (reported as CLH), per the amount of preparation that the assay uses: 0.93 mL/min
Compound 4: the middle estimate sits 1.4-fold (0.15 log units) above what was measured; the range from low to high includes it.
By their numbers in this assay, from the lowest: compounds 1, 4, 2 and 3 (each within the scatter of the next).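

For the compounds shown here, with the 3-chlorophenyl group held fixed on the shared core, the change from 3-cyanophenyl to 3,5-dichlorophenyl gives the first reading at the sulfonyl sulfur, and in this assay this step stays within the scatter (a 1.1-fold lower number from compound 2 to compound 4 (0.03 log units; within the scatter)). Going by these compounds alone, the nitrile with its hydrogen-bond acceptor leaves and chlorine enters, yet this single pair shows no step beyond the scatter, so the group on the sulfonyl sulfur has so far behaved like the aryl group in the earlier steps, none of which went beyond the scatter either. Nothing shown here offers an explanation for this outcome.

As far as these compounds go, the reading rests on one pair, so it remains open whether the same change would give a similar step with 3-methoxyphenyl or 4-methoxyphenyl in place of 3-chlorophenyl on the core. Also open, from the compounds shown here alone, is how this assay would respond to a group of a different kind on the sulfonyl sulfur, such as an amine, a longer alkyl chain or a phenyl ring carrying a carboxylic acid.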